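Solubility notes: anilino replacement on the shared core

A few compounds are considered here, and "the series" means these few. Any claim that something is new, unique, unknown or untested is made for them only; others in the source may bear on it.

Compound 1 `CN(c1ncco1)c1cnc(NCc2c(F)ccc3c2CCO3)n2cnnc12` is the most soluble of the numbers in hand: in a physicochemical assay for solubility, read by LC-MS, in phosphate buffer, with a stated time of 24 h, at pH 7.4 (a lower number here means a less soluble compound, a higher number a more soluble compound), compound 1 gives 67000 nM, which stands highest of the two readable values, with its nearest neighbour compound 3 a long way lower. Compound 3 `Cc1cc(-c2cnc(NCc3c(F)ccc4c3CCO4)c3cn[nH]c(=O)c23)n(C)n1` gives 1000 nM in this assay. Compound 2 `CC(=O)N1CCC(c2cnc(NCc3c(F)ccc4c3CCO4)c3cn[nH]c(=O)c23)CC1` returns only a limit in this assay, < 2000 nM, not a number. Among the compounds with values here, the one step between measured neighbours, a step that the limit leaves unreadable from compound 2 to compound 3, cannot be read in size because of the limit of < 2000 nM in this assay, at which 1 of the 3 values shown sits.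

Compound 4 `Fc1ccc2c(c1CNc1ncc(Nc3ccccc3)c3nncn13)CCO2` differs from compound 1 by anilino in place of methyl(1,3-oxazol-2-yl)amino on an aromatic carbon. Within the data shown here, no measured step touches this position on the shared core; the only pair that differs in one place sits on a different ring and is itself unreadable. Compounds 2 and 3 both carry a different core, so their numbers give no direct guide either. The expectation is therefore a drop of moderate size, a 4.5-fold lower number from compound 1 to compound 4 (0.65 log units; beyond the scatter), resting on nothing firmer than the wide spread already seen among the three compounds. Compound 4 is expected to give 15000 nM in this assay, with a range from 3000 nM to 60000 nM, and a real chance that only a limit is returned.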

Compound 4, solubility: 3000 nM
Compound 4: middle estimate off by 5.0-fold (0.70 log units), on the high side; the range from low to high includes it.
By their numbers in this assay, from the lowest: compound 3; then compound 4; then compound 1.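

Within the data shown here, the change to anilino in place of methyl(1,3-oxazol-2-yl)amino gives the first readable step in these notes, in this assay: a 22-fold lower number from compound 1 to compound 4 (1.35 log units; beyond the scatter). This aromatic carbon, ortho to a fused ring and para to a large group, therefore responds strongly to the choice of group, although both groups hold 7 heavy atoms; heavy-atom count alone does not set the number for this pair, which differs instead in ring type and in its counts of hydrogen-bond donors and acceptors. No measurement in hand bears on what lies behind this step.

One step at one position cannot separate the loss of the five-membered aromatic ring from the gain of the hydrogen-bond donor, and a methyl(phenyl)amino group on the same aromatic carbon, which keeps the carbon-only ring without the amine hydrogen, would pull these two apart. Also open, going by these compounds, is whether the same change would behave alike on the core of compound 3, and the step between compound 2 and compound 3 still cannot be read.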